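Anilinoquinazoline cinnamamides: aryl swap at the acrylamide

The compounds below may be only part of what the source reports. "The series", "measured", "known", "first", "only" and "open" are said of these compounds alone.

Compound 1 `O=C(/C=C/c1ccc([N+](=O)[O-])cc1)Nc1cc2c(Nc3ccc(F)c(Cl)c3)ncnc2cc1O[C@H]1CCOC1` carries a 4-nitrophenyl group on the acrylamide chain; in a functional assay on HeLa cells (Homo sapiens) for cytotoxicity, read by MTT assay, with a stated time of 72 h (a higher number here means a weaker inhibitor, a lower number a stronger inhibitor), compound 1 gives 27400 nM, the highest of the two numbers recorded in this assay. Compound 2 `COc1cc(/C=C/C(=O)Nc2cc3c(Nc4ccc(F)c(Cl)c4)ncnc3cc2O[C@H]2CCOC2)cc(OC)c1OC`, the 3,4,5-trimethoxyphenyl analogue, gives 24500 nM in this assay, and the step of a 1.1-fold lower number from compound 1 to compound 2 (0.05 log units; within the scatter) lies within the scatter. Compound 3 `COc1cc(/C=C/C(=O)Nc2cc3c(Nc4ccc(F)c(Cl)c4)ncnc3cc2OC)cc(OC)c1`, which carries a methoxy group in place of the tetrahydrofuranyloxy group, has in this assay only the entry "not determined" (no result reported), so no result is reported for compound 3 here.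

Compound 4 `COc1cc(/C=C/C(=O)Nc2cc3c(Nc4ccc(F)c(Cl)c4)ncnc3cc2O[C@H]2CCOC2)cc(OC)c1` is the next aryl variant. The change from compound 1 is 3,5-dimethoxyphenyl in place of 4-nitrophenyl on a double-bonded chain carbon bound to a double-bonded chain carbon. Going by the values given here, the only measured step that bears on it is the aryl swap a 1.1-fold lower number from compound 1 to compound 2 (0.05 log units; within the scatter), which left the number within the scatter; no measured step separates a trimethoxyphenyl from a dimethoxyphenyl analogue here. A step of no more than the scatter is therefore expected in this assay, with the estimated step of a 1.1-fold lower number from compound 1 to compound 4 (0.02 log units; within the scatter). For compound 4 the estimate in this assay is 26000 nM, with a range from 10000 nM to 60000 nM.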

Compound 4, half-maximal inhibitory concentration: 34300 nM
Beside the measured number, compound 4's estimate is 1.3-fold (0.12 log units) below it; the measured number falls inside the stated range.
By their numbers in this assay, from the lowest: compounds 2, 1 and 4 (each within the scatter of the next).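

In this assay, a second aryl swap at this place gives a 1.3-fold higher number from compound 1 to compound 4 (0.10 log units; within the scatter), so 3,5-dimethoxyphenyl joins 3,4,5-trimethoxyphenyl in reading no differently from 4-nitrophenyl on a double-bonded chain carbon bound to a double-bonded chain carbon. The first step linking the two methoxy-bearing analogues, hydrogen in place of methoxy on an aromatic carbon, gives a 1.4-fold higher number from compound 2 to compound 4 (0.15 log units; within the scatter), so this change also stays within the scatter, and across compounds 1, 2 and 4 the aryl group shows no effect on the number. No independent measurement bears on why these three aryl groups read alike.

On these data alone, whether a dimethylamino or carboxylic acid group on the phenyl ring, or a longer chain in place of the double-bonded one, would move the number beyond the scatter remains open. The step from the tetrahydrofuranyloxy group to the methoxy group of compound 3 cannot be read.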